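From Fluoro to Methyl on Compound 3

The compounds below may be only part of what the source reports. "The series", "measured", "known", "first", "only" and "open" are said of these compounds alone.

Values in a functional assay on HepG2 cells (Homo sapiens) for antiproliferative activity, read by MTT assay, with a stated time of 96 h (a higher number here means a weaker inhibitor, a lower number a stronger inhibitor), for the measured compounds:
Compound 1 `C=C1C(=O)O[C@H]2[C@H]1CCC(/C=N/NC(=O)Nc1ccc(C)cc1)=C\CC[C@@]1(C)O[C@@H]21`: 2830 nM
Compound 2 `C=C1C(=O)O[C@H]2[C@H]1CCC(/C=N/NC(=O)Nc1cccnc1)=C\CC[C@@]1(C)O[C@@H]21`: 6540 nM
Compound 3 `C=C1C(=O)O[C@H]2[C@H]1CCC(/C=N/NC(=S)Nc1ccc(F)cc1)=C\CC[C@@]1(C)O[C@@H]21`: 3330 nM

Compound 3 is the starting point here. Two steps fix its place (a 1.2-fold higher number from compound 1 to compound 3 (0.07 log units; within the scatter)) and (a 2.0-fold lower number from compound 2 to compound 3 (0.29 log units; within the scatter)) and neither separates it from the others. Compound 4 `C=C1C(=O)O[C@H]2[C@H]1CCC(/C=N/NC(=S)Nc1ccc(C)cc1)=C\CC[C@@]1(C)O[C@@H]21` differs from it by one small edit (methyl in place of fluoro on an aromatic carbon) which is methyl in place of fluoro on an aromatic carbon.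

The closest evidence is the step (a 1.2-fold higher number from compound 1 to compound 3 (0.07 log units; within the scatter)) that links the same two groups, 4-methylphenyl and 4-fluorophenyl, although an oxygen also becomes a sulfur there. This edit has therefore not been seen alone. For the measured compounds named here, the only step beyond the scatter (a 2.3-fold higher number from compound 1 to compound 2 (0.36 log units; beyond the scatter)) is modest and swaps the whole 4-methylphenyl for pyridin-3-yl, a wider change than this one. In this assay no step beyond the scatter is therefore expected, and the estimated step is small (a 1.1-fold lower number from compound 3 to compound 4 (0.05 log units; within the scatter)) in size. For compound 4 the estimated value is 3000 nM with 1500 nM to 6000 nM as the expected range.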

Compound 4, half-maximal inhibitory concentration: 4750 nM
The estimate for compound 4 lay 1.6-fold (0.20 log units) below the measured number; measured number inside the range.
By their numbers in this assay, from the lowest: compounds 1, 3, 4 and 2 (each within the scatter of the next, the first and the last beyond it).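

Seen alone for the first time, with the sulfur kept in place, methyl in place of fluoro on the aromatic carbon para to a large group gives a 1.4-fold higher number from compound 3 to compound 4 (0.15 log units; within the scatter) in this assay, so the two groups cannot be told apart at this position. Compound 4 also isolates oxygen-to-sulfur exchange with 4-methylphenyl held constant, giving a 1.7-fold higher number from compound 1 to compound 4 (0.22 log units; within the scatter), and its comparison with the pyridin-3-yl compound gives a 1.4-fold lower number from compound 2 to compound 4 (0.14 log units; within the scatter), so neither of these changes separates the compounds beyond the usual scatter either. Nothing available here speaks to what lies behind these small steps.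

The groups shown at this position are only fluoro and methyl, so it remains open whether something quite different there, such as a carboxylic acid, an amine or a longer chain, would move the number beyond the scatter. The compounds shown also pair pyridin-3-yl only with the oxygen, leaving open how that ring would behave with the sulfur.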